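Swapping a Cyclobutyl for a Fluorophenyl on a Cytotoxicity Screen

This account rests on a few compounds, and the source may have more. Where it says the series, first, only, none or still open, it means among the compounds named here.

Of the compounds shown here, three sharing one core have been tested in an ADME assay on Huh-7 cells (Homo sapiens) for cytotoxicity, with a stated time of 72 h; on this read-out lower numbers stand for higher toxicity in this test and higher numbers for lower toxicity in this test. Compound 1 `CC(C)(C)CCN1C(=O)C(C2=NS(=O)(=O)c3cc(NS(C)(=O)=O)ccc3N2)=C(O)C2CCCCC21` gives a value of > 33000 nM, which is a limit of the test rather than a number. Compound 2 `CS(=O)(=O)Nc1ccc2c(c1)S(=O)(=O)N=C(C1=C(O)C3CCCC3N(CC3CCC3)C1=O)N2` likewise reaches only a limit, > 33000 nM. Compound 3 `CS(=O)(=O)Nc1ccc2c(c1)S(=O)(=O)N=C(C1=C(O)[C@H]3CCC[C@H]3N(CC3CC3)C1=O)N2` also stops at a limit, > 33000 nM. Compound 2 therefore stands at the same place as the other two, because of the limit of > 33000 nM in this assay, at which 3 of the 3 values shown sit; no true difference among the three can be read from these values.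

Compound 4 `CS(=O)(=O)Nc1ccc2c(c1)S(=O)(=O)N=C(C1=C(O)C3CCCC3N(Cc3cccc(F)c3)C1=O)N2` has not yet been measured in this assay . It differs from compound 2 by a single change: 3-fluorophenyl in place of cyclobutyl on a saturated chain carbon bound to an amide-type nitrogen in a ring. Within the data shown here, no pair of measured compounds with a single change is available to calibrate this step. Given that every value so far sits at the limit, the expected step from compound 2 to compound 4 is a number no higher from compound 2 to compound 4 (the limit leaves the size open), essentially none beyond the scatter. Compound 4 is thus estimated at 33000 nM, within a range from 15000 nM to 100000 nM, most likely again reported as a limit.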

Compound 4, half-maximal cytotoxic concentration: > 33000 nM
Compound 4: no number, only a limit; the forecaster's own chance of this, stated with the estimate: 75%; the middle value lies on the limit itself.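

In this assay compound 4 gives > 33000 nM, which is a limit and not a number. Among these compounds, compound 2 also stands at a limit, so no step from compound 2 to compound 4 can be read. The compounds shown leave open at what concentration any of them would harm these cells: the limit of > 33000 nM in this assay, at which 4 of the 4 values shown sit.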